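The compounds below may be only part of what the source reports. "The series", "measured", "known", "first", "only" and "open" are said of these compounds alone.

Compound 1 `CC1CCN(c2c(S(=O)(=O)c3cc(F)cc(F)c3)cnc3cc(F)ccc23)CC1`: in an assay on isolated protein for displacement of a labelled ligand from metabotropic glutamate receptor 5 (Homo sapiens), with a stated time of 60 min, tested at 1 uM (a lower number here means less inhibition, a higher number more inhibition at the concentration tested (going by the name of the read-out)), compound 1 gives 77%.
Compound 2 `CC1CCN(c2c(S(=O)(=O)c3cccc(Cl)c3)cnc3cc(Cl)ccc23)CC1`: compound 2 gives 92%.
Compound 3 `COc1ccc2ncc(S(=O)(=O)c3cccc(F)c3)c(N3CCC(C)CC3)c2c1`: compound 3 gives 68%.

Among these three, compound 2 shows the highest inhibition in this assay; compound 1 lies below it by more than the usual scatter, and compound 3 lies further below, also beyond the scatter. The new compound 4 `Cc1ccc(S(=O)(=O)c2cnc3cc(Cl)ccc3c2N2CCC(C)CC2)cc1F` differs from compound 2 in one place, (3-fluoro-4-methylphenyl in place of 3-chlorophenyl on a sulfonyl sulfur). Among the measured compounds shown here, no step between measured compounds of this kind is available, so the size of the change cannot be read from a precedent. The step from compound 2 to compound 4 is expected to be modest and downward, a number 8 percentage points lower from compound 2 to compound 4 (within the scatter), quite possibly not beyond the scatter. Compound 4 is therefore estimated at 84%, in the range 68% to 97%.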

Compound 4, a percentage reported as inhibition, at one concentration (the size of the read-out at that concentration, not a potency): 85%
For compound 4 the middle estimate is 1 percentage points below the measured one; low and high end bracket the measured number.
By their numbers in this assay, from the lowest: compounds 3, 1, 4 and 2 (each within the scatter of the next, the first and the last beyond it).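

In this assay, putting 3-fluoro-4-methylphenyl in place of 3-chlorophenyl on a sulfonyl sulfur gives a number 7 percentage points lower from compound 2 to compound 4 (within the scatter). Among the compounds shown here, this is the one comparison here that isolates this position, and it shows that the aryl group can lose its chlorine and gain a fluorine and a methyl without a change that can be told from the scatter. Nothing available explains this result. As far as these compounds go, it remains open whether this position accepts a phenyl group carrying an amine or a carboxylic acid. From the compounds shown here alone, it also remains open whether the same exchange would give a similar step on the cores of compound 1 and compound 3.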